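From Pyridin-2-yl to Thiophen-3-yl on the Shared Core

The source may hold more compounds than are shown below. What is called first, only, known or untested is meant among the compounds shown, and "the series" means these compounds.

Going by the values given here, compound 2, `OC[C@H]1O[C@@H](n2cc(-c3ccccn3)nn2)[C@H](O)[C@@H]1O`, is the only member of this small set with a true number: in a functional assay on CCRF-CEM cells (Homo sapiens) (on this read-out lower numbers stand for stronger inhibition and higher numbers for weaker inhibition), compound 2 gives 245000 nM. Compound 1, `NC(=O)c1cn([C@@H]2O[C@H](CO)[C@@H](O)[C@H]2O)nn1`, reaches only a limit of this assay, at which compound 1 gives > 200000 nM. The two differ by pyridin-2-yl in place of carbamoyl on an aromatic carbon, yet a step that the limit leaves unreadable from compound 1 to compound 2, as the limit of > 200000 nM in this assay, at which 1 of the 2 values shown sits, makes clear.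

Compound 3, `OC[C@H]1O[C@@H](n2cc(-c3ccsc3)nn2)[C@H](O)[C@@H]1O`, has not yet been measured. Its change from compound 2 is thiophen-3-yl in place of pyridin-2-yl on an aromatic carbon. Among the compounds with values here, no measured step touches this exchange; the single step that exists, from compound 1 to compound 2, is unreadable and concerns a different group. There is thus no ground for expecting a step beyond the usual scatter in this assay, in either direction. Compound 3 is therefore estimated at 245000 nM, within a range from 80000 nM to 800000 nM. The expected step is no change at the digits printed from compound 2 to compound 3 (within the scatter), a size that stays inside the scatter.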

Compound 3, half-maximal inhibitory concentration: 139000 nM
Compound 3: the middle estimate sits 1.8-fold (0.25 log units) above what was measured; the range from low to high includes it.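

In this assay, thiophen-3-yl in place of pyridin-2-yl gives a 1.8-fold lower number from compound 2 to compound 3 (0.25 log units; within the scatter), so this carbon of the five-membered aromatic ring now has a readable exchange between two aromatic groups, and compound 2 and compound 3 cannot be told apart on this read-out. Putting thiophen-3-yl in place of carbamoyl gives an at least 1.4-fold lower number from compound 1 to compound 3 (0.15 log units; that floor lies within the scatter), which is only a floor for the true step, although it can at least be sized, whereas the step from carbamoyl to pyridin-2-yl cannot be read. That floor depends on compound 1, whose value is a limit and not a number: the limit of > 200000 nM in this assay, at which 1 of the 3 values shown sits.

The compounds shown leave open whether any group on this carbon can move the number beyond the scatter, and the true size of the step away from carbamoyl remains unknown. An amine, a carboxylic acid or a longer carbon chain at this position would test whether the read-out responds to groups other than the aromatic rings and the carbamoyl seen here.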